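The source may hold more compounds than are shown below. What is called first, only, known or untested is meant among the compounds shown, and "the series" means these compounds.

Measured compounds in an assay on CHO cells for displacement of a labelled ligand from adenosine receptor A3 (Homo sapiens), read by scintillation counting, with a stated time of 3 h; a lower number here means a stronger inhibitor, a higher number a weaker inhibitor:
- compound 1, `Cc1nc(N)c2nc(-c3ccccc3)sc2n1`: compound 1 gives 2660 nM
- compound 2, `Nc1nc(-c2ccccc2)nc2sc(-c3ccccc3)nc12`: compound 2 gives 84 nM
- compound 3, `Nc1nc(-c2ccc(CO)cc2)nc2sc(-c3ccccc3)nc12`: compound 3 gives 8.2 nM

Compound 3 has the lowest number of the three in this assay. Its nearest neighbour is compound 2, separated by a 10-fold lower number from compound 2 to compound 3 (1.01 log units; beyond the scatter), and compound 1 lies furthest away, separated by a 320-fold lower number from compound 1 to compound 3 (2.51 log units; beyond the scatter). Compound 2 itself already stands well apart from compound 1, as a 32-fold lower number from compound 1 to compound 2 (1.50 log units; beyond the scatter) shows.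

Compound 4, `COc1ccc(-c2nc(N)c3nc(-c4ccccc4)sc3n2)cc1`, differs from compound 3 in one place: methoxy in place of hydroxymethyl on an aromatic carbon. Within the data shown here, none of the measured steps makes exactly this exchange. The closest guide is a 10-fold lower number from compound 2 to compound 3 (1.01 log units; beyond the scatter), which shows how much the bare phenyl of compound 2 gains when the hydroxymethyl is put in; compound 4 keeps a group of the same size at the same place, but as a methoxy, which keeps the one hydrogen-bond acceptor and loses the hydrogen-bond donor. Part of the gain seen in compound 3 may therefore be kept and part lost. Compound 4 is expected to land between compound 2 and compound 3, nearer to compound 3, which means a modest expected rise of a 3.0-fold higher number from compound 3 to compound 4 (0.48 log units; beyond the scatter). The estimate for compound 4 in this assay is 25 nM, within 6 nM to 100 nM.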

Compound 4, inhibition constant: 46.7 nM
Compound 4: middle estimate off by 1.9-fold (0.27 log units), on the low side, and the stated range covers the measured number.
By their numbers in this assay, from the lowest: compound 3; then compounds 4 and 2 (each within the scatter of the next); then compound 1.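

In this assay the exchange of hydroxymethyl for methoxy keeps the same atoms at the same place, yet it brings a 5.7-fold higher number from compound 3 to compound 4 (0.76 log units; beyond the scatter) and removes the hydrogen-bond donor, so at this position how the atoms are joined matters, and not only how many there are. Methoxy does not reproduce the gain that hydroxymethyl gave: a 1.8-fold lower number from compound 2 to compound 4 (0.25 log units; within the scatter) stays within the scatter, so methoxy cannot be told apart from hydrogen on this aromatic carbon, while a 57-fold lower number from compound 1 to compound 4 (1.76 log units; beyond the scatter) shows that 4-methoxyphenyl still stands far from methyl. No measurement shown here explains the difference between hydroxymethyl and methoxy, so the part played by the donor stays unsettled.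

A longer chain ending in a hydroxyl, such as hydroxyethyl, would show whether the gain survives when that hydroxyl sits further out on the same aromatic carbon. An aminomethyl group or a carboxylic acid at this place would show whether a different group carrying hydrogens on a heteroatom can match hydroxymethyl, or whether the gain is particular to that group.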